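A few compounds are considered here, and "the series" means these few. Any claim that something is new, unique, unknown or untested is made for them only; others in the source may bear on it.

Measured in a functional assay on V79-379A cells (Cricetulus griseus) for cytotoxicity, read by MTT assay, in the presence of a further agent that is not named here; a higher number here means a weaker inhibitor, a lower number a stronger inhibitor:
- compound 1 `COC1=CC(=O)c2c(c(CO)cn2C)C1=O`: 240000 nM
- compound 2 `COC1=CC(=O)c2c(c(CO)c(C3CC3)n2C)C1=O`: 820000 nM

Compound 1 has the lower number of the two, so it is the stronger inhibitor. Compound 3 `COC1=CC(=O)c2c(c(CCl)cn2C)C1=O` carries chloro in place of hydroxy on a saturated chain carbon bound to an aromatic carbon. Within the data shown here, the only measured step is a 3.4-fold higher number from compound 1 to compound 2 (0.53 log units; beyond the scatter), a modest change beyond the scatter. It involves cyclopropyl in place of hydrogen on an aromatic carbon, a different change at a different place, so it offers only a loose guide to size. A larger move toward stronger inhibition in this assay is expected, though this is uncertain. The expected change is a 6.0-fold lower number from compound 1 to compound 3 (0.78 log units; beyond the scatter). For compound 3 the estimated value is 40000 nM, with an expected range of 4000 nM to 250000 nM.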

Compound 3, half-maximal inhibitory concentration: 33000 nM
Compound 3: the middle estimate sits 1.2-fold (0.08 log units) above what was measured; measured number inside the range.
By their numbers in this assay, from the lowest: compound 3; then compound 1; then compound 2.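

In this assay, among these compounds, the change from hydroxymethyl to chloromethyl gives a 7.3-fold lower number from compound 1 to compound 3 (0.86 log units; beyond the scatter) and is the first sign that the group on this saturated chain carbon can shift the number toward stronger inhibition. The change replaces a hydroxy, counted as one hydrogen-bond donor and one acceptor, with a chloro, counted as neither, but no measurement here explains the drop. On these data alone, whether bromo, an amine or a longer chain on this carbon would go further remains open. So does whether chloromethyl would give a similar step alongside the cyclopropyl of compound 2.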